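Longer amide arm in place of the direct amide of compound 3

The compounds below may be only part of what the source reports. "The series", "measured", "known", "first", "only" and "open" are said of these compounds alone.

In a functional assay on HepG2 cells (Homo sapiens) for antiproliferative activity, read by CCK-8 assay, with a stated time of 72 h, tested at 2 uM (on this read-out lower numbers stand for a weaker effect and higher numbers for a stronger effect at the one concentration tested), compound 3 `Nc1ccccc1NC(=O)c1ccc(COCNc2nc(Nc3ccccc3)c3ncn(C4CCCC4)c3n2)cc1` gives 37.5%, the highest of the three numbers in hand. Compound 2 `Nc1ccccc1NC(=O)/C=C/c1ccc(COCNc2nc(Nc3cccc(Cl)c3)c3ncn(C4CCCC4)c3n2)cc1` gives 9.67%, a number lower by more than the scatter, and compound 1 `CC(C)n1cnc2c(Nc3ccccc3)nc(NCOCc3ccc(/C=C/C(=O)Nc4ccccc4N)cc3)nc21` gives 1.46%, the furthest below. Compound 4 `Nc1ccccc1NC(=O)/C=C/c1ccc(COCNc2nc(Nc3ccccc3)c3ncn(C4CCCC4)c3n2)cc1` has not been measured. It differs from compound 3 in one place: 2-((2-aminophenyl)carbamoyl)ethenyl in place of (2-aminophenyl)carbamoyl on an aromatic carbon. Among the compounds with values here, no measured pair differs in this place alone, so the size of the step is not known directly. Because compound 2 gives 9.67% while carrying the entering group, a drop beyond the scatter is expected, a number 25.5 percentage points lower from compound 3 to compound 4 (beyond the scatter). Compound 4 is estimated to give 12%, in the range 2% to 30%.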

Compound 4, a percentage reported as inhibition, at one concentration (the size of the read-out at that concentration, not a potency): 2.93%
For compound 4 the middle estimate is 9.1 percentage points above the measured one; measured number inside the range.
By their numbers in this assay, from the lowest: compounds 1, 4 and 2 (each within the scatter of the next); then compound 3.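

In this assay this position now has a direct measure: the step is a number 34.6 percentage points lower from compound 3 to compound 4 (beyond the scatter) with 2-((2-aminophenyl)carbamoyl)ethenyl in place of (2-aminophenyl)carbamoyl. With the ethenyl arm held constant, the step is a number 6.7 percentage points lower from compound 2 to compound 4 (within the scatter) for hydrogen in place of chloro and a number 1.5 percentage points higher from compound 1 to compound 4 (within the scatter) for cyclopentyl in place of isopropyl, so among these four compounds only compound 3 lacks the arm and only compound 3 stands apart. No measurement here gives a reason for the drop.

Open, going by these compounds, is whether a saturated two-carbon chain or a longer chain at this position would keep the number of compound 3. Also open, on these data alone, is what chloro or isopropyl would do on the direct amide.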